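The source may report more compounds than this note shows. Statements on the series, on what has been measured and on what is new or still open speak of the compounds shown alone.

Measured so far in an assay on CHO cells for displacement of a labelled ligand from adenosine receptor A2b (Homo sapiens), read by scintillation counting, with a stated time of 75 min, in the presence of a further agent that is not named here; on this read-out higher numbers stand for weaker inhibition and lower numbers for stronger inhibition:

compound 1, `CCCn1c(=O)[nH]c2nc(-c3ccc(S(=O)(=O)N4CCN(c5cccc(Br)c5)CC4)cc3)[nH]c2c1=O`: 0.234 nM
compound 2, `CCCn1c(=O)c2[nH]c(-c3ccc(S(=O)(=O)N4CCN(c5ccc(Cl)cc5)CC4)cc3)nc2n(CC)c1=O`: 4.31 nM
compound 3, `CCCn1c(=O)[nH]c2nc(-c3ccc(S(=O)(=O)N4CCN(c5ccccc5)C(C)C4)cc3)[nH]c2c1=O`: 7.15 nM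

Among these three, compound 1 stands lowest in this assay, and its gap to compound 2, the nearest of the other two, is well beyond the usual scatter of repeated measurements, as is its larger gap to compound 3. Compound 1 is therefore the strongest inhibitor of the three on this read-out. Compound 2 and compound 3 differ from compound 1 in more than one place, so neither pair gives a single-change step; only their values themselves can be compared.

The step followed here leads from compound 1 to compound 4, `CCCn1c(=O)[nH]c2nc(-c3ccc(S(=O)(=O)N4CCN(c5ccccc5Cl)CC4)cc3)[nH]c2c1=O`, which has not yet been measured. The change is 2-chlorophenyl in place of 3-bromophenyl on an amine nitrogen in a ring. The shared core and the rest of the molecule are unchanged; only the aryl group on the amine nitrogen in a ring is exchanged.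

Going by the values given here, no measured pair shows this exact change, so the step is judged only from the structures. A modest rise in the number, that is weaker inhibition, of roughly a 5.1-fold higher number from compound 1 to compound 4 (0.71 log units; beyond the scatter) is expected, possibly just beyond the scatter. Compound 4 is thus estimated at 1.2 nM, within a range from 0.3 nM to 5 nM.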

Compound 4, inhibition constant: 0.403 nM
The estimate for compound 4 lay 3.0-fold (0.47 log units) above the measured number; the range from low to high includes it.
By their numbers in this assay, from the lowest: compounds 1 and 4 (each within the scatter of the next); then compounds 2 and 3 (each within the scatter of the next).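

In this assay, putting 2-chlorophenyl in place of 3-bromophenyl on an amine nitrogen in a ring gives a 1.7-fold higher number from compound 1 to compound 4 (0.24 log units; within the scatter), so this read-out does not separate the two compounds. Going by these compounds alone, this is the first comparison that differs in one place only, and it shows that, on this core, the aryl group on this nitrogen can be exchanged from one halogen-bearing phenyl to another without a shift that exceeds the usual scatter, even though both the halogen and its position on the phenyl ring differ. No measurement at hand bears on why the two groups read alike.

On these data alone, the step changes the halogen and its position together, so what each contributes alone remains open, as does whether the same result would hold for 3-chlorophenyl or 2-bromophenyl on the same core. Also open, as far as these compounds go, is how far this tolerance extends beyond halogen-bearing phenyl groups, for instance to a phenyl ring carrying a methoxy group or a carboxylic acid, or to a cyclohexyl ring in place of the aryl group.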